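Hydrazone series: replacing the nitrophenyl on the acyl urea

A few compounds are considered here, and "the series" means these few. Any claim that something is new, unique, unknown or untested is made for them only; others in the source may bear on it.

Compound 1 `CN(C(=O)NC(=O)c1ccc([N+](=O)[O-])cc1)c1nc(C(F)(F)F)c(C(=O)N/N=C/c2cccc(C(F)(F)F)c2)s1` is the reference point of this small set. In a functional assay on HeLa cells (Homo sapiens) for inhibition, read by MTT assay, with a stated time of 72 h (on this read-out higher numbers stand for weaker inhibition and lower numbers for stronger inhibition), compound 1 gives 4.12 ug/mL, the lowest number of the three measured compounds. Compound 2 `CN(C(=O)NC(=O)c1ccc([N+](=O)[O-])cc1)c1nc(C(F)(F)F)c(C(=O)N/N=C/c2ccc([N+](=O)[O-])cc2)s1` gives 8.42 ug/mL in this assay, and compound 3 `CN(C(=O)NC(=O)c1ccc(F)c(F)c1)c1nc(C(F)(F)F)c(C(=O)N/N=C/c2ccccc2C(F)(F)F)s1` gives 9.24 ug/mL. Among the compounds with values here, the single one-place step known, a 2.0-fold higher number from compound 1 to compound 2 (0.31 log units; beyond the scatter), concerns the aryl group on the carbon with a double bond to nitrogen and not the acyl part of the urea. Compound 3 differs from compound 1 in two places at once, so its value can only be set beside that of compound 1 without assigning the difference to either change.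

Compound 4 `CN(C(=O)NC(=O)c1ccc(Cl)cc1Cl)c1nc(C(F)(F)F)c(C(=O)N/N=C/c2cccc(C(F)(F)F)c2)s1` alters the other end of the molecule: 2,4-dichlorophenyl in place of 4-nitrophenyl on a carbonyl carbon. Within the data shown here, no measured step touches this position, so nothing in the data says how the number moves when the acyl aryl group changes. The three measured values all sit within a narrow band, which suggests this assay is not strongly sensitive to the aryl groups tried so far. Compound 4 is therefore expected to come out near compound 1, with a wide range, estimated at 6 ug/mL (2.5 ug/mL to 15 ug/mL), a step of a 1.5-fold higher number from compound 1 to compound 4 (0.16 log units; within the scatter) that is expected to stay close to the scatter.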

Compound 4, half-maximal inhibitory concentration: 9.6 ug/mL
Estimate against measurement, compound 4: 1.6-fold (0.20 log units) below, within the range that was stated.
By their numbers in this assay, from the lowest: compound 1; then compounds 2, 3 and 4 (each within the scatter of the next).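

The acyl aryl group on the carbonyl carbon is not a silent position in this assay: 2,4-dichlorophenyl in place of 4-nitrophenyl gives a 2.3-fold higher number from compound 1 to compound 4 (0.37 log units; beyond the scatter), the first one-place step read at this end of the molecule. Together with a 2.0-fold higher number from compound 1 to compound 2 (0.31 log units; beyond the scatter), it shows that a single change at either end of the molecule has so far given a higher number than the reference, with no exception among these two steps. No supporting evidence on this change is at hand to account for the step.

The change removes 4-nitrophenyl and brings in two chlorine atoms at once, so the step does not show whether either chlorine alone would give the same reading, and an unsubstituted phenyl, an aryl group carrying an amine or a carboxylic acid, or a saturated alkyl chain on the same carbonyl carbon would extend the comparison. Also open, from the compounds shown here alone, is whether the step would hold with 4-nitrophenyl, rather than 3-(trifluoromethyl)phenyl, on the carbon with a double bond to nitrogen.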